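The compounds below may be only part of what the source reports. "The series", "measured", "known", "first", "only" and "open" are said of these compounds alone.

Working notes on the series around compound 2 `CC(C)(C)OC(=O)N1CCC(Oc2ncnc3c2CCN3c2ccc(S(C)(=O)=O)cc2F)CC1`. In a functional assay on CHO-K1 cells for agonist activity at Glucose-dependent insulinotropic receptor (Homo sapiens), read by a luciferase reporter, with a stated time of 5 h (a higher number here means that more compound is needed for the effect, a lower number that less compound is needed), compound 2 gives 20 nM, the lowest of the three numbers in hand. Compound 3 `COCCOC(=O)N1CCC(Oc2ncnc3c2CCN3c2ccc(S(C)(=O)=O)cc2F)CC1` gives 316 nM in this assay, and the step of a 16-fold higher number from compound 2 to compound 3 (1.20 log units; beyond the scatter) lies beyond the scatter. Compound 1 `CC(C)OC(=O)N1CCC(Oc2cccc3c2CCN3c2ccc(S(C)(=O)=O)cc2)CC1` gives 501 nM in this assay; it differs from compound 2 in more than one place, so only the two values can be set side by side, and of the measured compounds it stands furthest from compound 2.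

The next compound, compound 4 `CS(=O)(=O)c1ccc(N2CCc3c(OC4CCN(C(=S)Sc5ccccc5)CC4)ncnc32)c(F)c1`, differs from compound 2 in one place: a group of 9 heavy atoms (7 carbon, 2 sulfur; one six-membered aromatic ring of carbon only) in place of a group of 7 heavy atoms (5 carbon, 2 oxygen; no ring), on an amine nitrogen in a ring. Going by the values given here, the only measured step that bears on this position is a 16-fold higher number from compound 2 to compound 3 (1.20 log units; beyond the scatter), where exchanging one part of the tert-butoxycarbonyl group already cost a large amount. The step to compound 4 removes the whole tert-butoxycarbonyl group and brings in a group for which no measured comparison exists, so the expectation rests on that single step and carries a wide range. A loss beyond the scatter is expected rather than a gain. Compound 4 is expected to give 250 nM in this assay, with a range from 50 nM to 1500 nM. The step this estimate implies is a 13-fold higher number from compound 2 to compound 4 (1.10 log units; beyond the scatter).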

Compound 4, half-maximal effective concentration: 12.6 nM
The estimate for compound 4 lay 20-fold (1.30 log units) above the measured number, and the stated range ends above it.
By their numbers in this assay, from the lowest: compounds 4 and 2 (each within the scatter of the next); then compounds 3 and 1 (each within the scatter of the next).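

On the amine nitrogen in a ring, the tert-butoxycarbonyl group can be replaced by a group of 9 heavy atoms (7 carbon, 2 sulfur; one six-membered aromatic ring of carbon only) with only a 1.6-fold lower number from compound 2 to compound 4 (0.20 log units; within the scatter) in this assay, so a low number here does not depend on keeping tert-butoxycarbonyl. The cost seen earlier, a 16-fold higher number from compound 2 to compound 3 (1.20 log units; beyond the scatter), is therefore not a general cost of replacing that group, and the same position separates the 2-methoxyethyl and sulfur-bearing groups by a 25-fold lower number from compound 3 to compound 4 (1.40 log units; beyond the scatter), which makes the identity of the replacement decisive among these three compounds. No measurement in hand explains this separation.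

The compounds shown leave open whether the aromatic ring or the sulfur atoms of the entering group matter more; a phenoxycarbonyl group, which keeps the ring with oxygen in place of sulfur, and a methylsulfanylthiocarbonyl group, which keeps both sulfur atoms without the ring, would pull these apart. Also open, as far as these compounds go, is how an isopropoxycarbonyl group behaves on the core of compound 2, as compound 1 differs from compound 2 in more than one place.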